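The compounds below may be only part of what the source reports. "The series", "measured", "known", "first", "only" and "open" are said of these compounds alone.

Measured so far: compound 1 `COc1ccc(/C=C2\CCC/C(=C\c3cccc(OC)c3OC)C2=O)cc1` with 13600 nM, and compound 2 `COc1ccc(/C=C2\CCC/C(=C\c3cccc(Cl)c3)C2=O)cc1OC` with 5100 nM, both in a functional assay on SW-620 cells (Homo sapiens) for cytotoxicity, read by MTT assay, with a stated time of 72 h; on this read-out higher numbers stand for weaker inhibition and lower numbers for stronger inhibition.

Compound 2 holds the lowest of the two numbers; compound 1 sits well above it, a gap the two values themselves show. Compound 3 `COc1cc(/C=C2\CCC/C(=C\c3ccc(OC)c(OC)c3)C2=O)ccc1O` keeps the core of compound 2 and changes one side: 4-hydroxy-3-methoxyphenyl in place of 3-chlorophenyl on a double-bonded chain carbon bound to a double-bonded ring carbon. For the measured compounds named here, with no measured step of this kind to draw on, the expected change from compound 2 to compound 3 is a 1.6-fold higher number from compound 2 to compound 3 (0.20 log units; within the scatter), a modest move toward a higher number that may not clear the scatter. Compound 3 is therefore estimated at 8000 nM, within 2500 nM to 25000 nM.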

Compound 3, half-maximal inhibitory concentration: 4500 nM
Compound 3: middle estimate off by 1.8-fold (0.25 log units), on the high side, and the stated range covers the measured number.
By their numbers in this assay, from the lowest: compounds 3 and 2 (each within the scatter of the next); then compound 1.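

In this assay, putting 4-hydroxy-3-methoxyphenyl in place of 3-chlorophenyl on a double-bonded chain carbon bound to a double-bonded ring carbon gives a 1.1-fold lower number from compound 2 to compound 3 (0.05 log units; within the scatter) and so leaves no readable difference at this position. The entering group carries a hydrogen-bond donor and hydrogen-bond acceptors, the leaving group none, yet the two values remain within the scatter of each other. No measurement at hand accounts for this result. From the compounds shown here alone, whether an amine or a carboxylic acid in this place would give a similar number remains open.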